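The source may report more compounds than this note shows. Statements on the series, on what has been measured and on what is new or still open speak of the compounds shown alone.

Compound 1 `COc1ccc(NC(=S)NC(=O)c2cn(-c3ccccc3)nc2-c2ccc(OC)cc2)cc1` carries a methoxy group on each of its two outer phenyl rings, and in a functional assay on A549 cells (Homo sapiens) for inhibition, read by CCK-8 assay, with a stated time of 48 h (on this read-out lower numbers stand for stronger inhibition and higher numbers for weaker inhibition), compound 1 gives 750 nM. That is the lowest of the three numbers available. Compound 2 `O=C(NC(=S)Nc1ccc(Cl)cc1)c1cn(-c2ccccc2)nc1-c1ccc(Cl)cc1` replaces both methoxy groups with chloro and gives 3150 nM, and compound 3 `O=C(NC(=S)Nc1ccc(Cl)cc1)c1cn(-c2ccccc2)nc1-c1ccccc1` keeps the chloro on the anilino ring but not on the ring attached to the core, giving 3200 nM. Going by the values given here, the only single-point step among the measured compounds is a 1.0-fold higher number from compound 2 to compound 3 (0.01 log units; within the scatter), and it concerns the ring joined to the core rather than the anilino ring.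

Compound 4 `COc1ccc(-c2nn(-c3ccccc3)cc2C(=O)NC(=S)Nc2ccc(C)cc2)cc1` differs from compound 1 in one place: methyl in place of methoxy on an aromatic carbon. Among the compounds with values here, no measured step touches this position, so the only guide is that the one comparable swap on the other ring, from compound 2 to compound 3, stayed within the scatter, while the two-ring exchange of methoxy for chloro separated compound 1 from compound 2 by more than the scatter. A modest step in this assay is therefore expected, with no firm direction, and compound 4 is estimated at 1100 nM, within 450 nM to 2700 nM, corresponding to an expected change of a 1.5-fold higher number from compound 1 to compound 4 (0.17 log units; within the scatter).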

Compound 4, half-maximal inhibitory concentration: 1250 nM
Compound 4: the middle estimate sits 1.1-fold (0.06 log units) below what was measured; the range from low to high includes it.
By their numbers in this assay, from the lowest: compounds 1 and 4 (each within the scatter of the next); then compounds 2 and 3 (each within the scatter of the next).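

Going by these compounds alone, the exchange of methoxy for methyl on the anilino ring gives, in this assay, a 1.7-fold higher number from compound 1 to compound 4 (0.22 log units; within the scatter), and this is the first single-place step at that ring, as the earlier step concerned the ring joined to the core. It shows that the oxygen of the methoxy group can leave this ring, with a small carbon group kept on the same carbon, while the number stays within the scatter of that of compound 1, so this pair gives no sign that the position needs methoxy specifically. No measurement is available that would explain this result.

The compounds shown leave open how far this tolerance extends, since methoxy and methyl are the only two groups compared here on the anilino ring with the rest of the molecule held constant, and an amine, a hydroxyl, a carboxylic acid or a longer chain such as butyl in the same place could behave differently. They also leave open what happens when the methoxy group on the ring joined to the core is changed alone, as no single-place step among these compounds touches it.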